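Expected Cytotoxicity After a Hydroxyphenyl-for-Chlorophenyl Swap

This account rests on a few compounds, and the source may have more. Where it says the series, first, only, none or still open, it means among the compounds named here.

In a toxicity assay on MCF-10A cells (Homo sapiens) for cytotoxicity, read by MTT assay, with a stated time of 48 h (on this read-out higher numbers stand for weaker inhibition and lower numbers for stronger inhibition), three compounds have been measured:
compound 1 `O=C(/C=C/c1ccc2c(c1)B(O)OC2)c1ccc(-c2ccccc2)cc1` gives 20700 nM
compound 2 `O=C(/C=C/c1ccc2c(c1)B(O)OC2)c1ccc(Cl)cc1` gives 12100 nM
compound 3 `O=C(/C=C/c1ccc2c(c1)B(O)OC2)c1ccc(C(F)(F)F)cc1` gives 22300 nM

Compound 2 holds the lowest of the three numbers, yet the steps of a 1.7-fold lower number from compound 1 to compound 2 (0.23 log units; within the scatter) and a 1.8-fold higher number from compound 2 to compound 3 (0.27 log units; within the scatter) both fall within the scatter, as does a 1.1-fold higher number from compound 1 to compound 3 (0.03 log units; within the scatter), so the three compounds are not told apart. Compound 4 `O=C(/C=C/c1ccc2c(c1)B(O)OC2)c1ccccc1O` is not yet measured. It differs from compound 2 by 2-hydroxyphenyl in place of 4-chlorophenyl on a carbonyl carbon. Among the compounds with values here, no measured step changes the whole group on the carbonyl carbon, so none bears on it directly; the three measured steps, all within the scatter, only show that varied groups there gave similar numbers. The step of a 1.2-fold higher number from compound 2 to compound 4 (0.09 log units; within the scatter) is therefore expected to stay within the scatter. Compound 4 is estimated at 15000 nM, between 5000 nM and 45000 nM.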

Compound 4, half-maximal inhibitory concentration: 53700 nM
For compound 4 the middle estimate is 3.6-fold (0.55 log units) below the measured one, outside the stated range (above it).
By their numbers in this assay, from the lowest: compounds 2, 1 and 3 (each within the scatter of the next); then compound 4.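

In this assay, within the data shown here, the change of group on the carbonyl carbon gives a 4.4-fold higher number from compound 2 to compound 4 (0.65 log units; beyond the scatter) and is the only step here beyond the scatter, so the group held at this place can matter, although the three earlier groups could not be told apart. The entering 2-hydroxyphenyl has a hydrogen-bond donor and a hydrogen-bond acceptor that 4-chlorophenyl lacks, and its name also shows a different ring position, so more than one thing changes at once.

As far as these compounds go, whether an amine or a carboxylic acid on that ring would behave like the hydroxyl remains open. Nothing available gives a reason for this step.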